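A few compounds are considered here, and "the series" means these few. Any claim that something is new, unique, unknown or untested is made for them only; others in the source may bear on it.

Measured in a functional assay on aorta (Rattus norvegicus) for inhibition; on this read-out lower numbers stand for an effect already at smaller amounts and higher numbers for an effect only at larger amounts of compound:

- Compound 1 `CCCNC1=NS(=O)(=O)c2cccc(Cl)c2N1`: 180000 nM
- Compound 2 `O=S1(=O)N=C(NC2CC2)Nc2cc(Cl)ccc21`: 156000 nM
- Compound 3 `CCNC1=NS(=O)(=O)c2cc(Cl)ccc2N1`: 39900 nM

Compound 3 has the lowest number of the three, so it shows its effect at the smallest amount. The gaps from compound 3 up to compound 2 and to compound 1 are both beyond the usual scatter of repeat measurements.

The next compound to test is compound 4 `O=S1(=O)N=C(NC2CC2)Nc2ccc(Cl)cc21`. It has cyclopropyl in place of ethyl on an amine nitrogen, and the other neighbour of that nitrogen is a carbon with a double bond to nitrogen (cyclopropyl in place of ethyl on an amine nitrogen). In other words, ethylamino becomes cyclopropylamino.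

For the measured compounds named here, no pair of measured compounds here differs in one place only, so the data give no direct measure of this swap. The change itself is small, so the likeliest outcome in this assay is no step beyond the scatter, with any drift more likely towards a lower number than a higher one. The estimated change is a 1.4-fold lower number from compound 3 to compound 4 (0.15 log units; within the scatter). For compound 4 the expected value is 28000 nM, with an estimated range of 9000 nM to 80000 nM.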

Compound 4, half-maximal effective concentration: 191000 nM
Compound 4: the middle estimate sits 6.8-fold (0.83 log units) below what was measured; the measured number lies above the stated range.
By their numbers in this assay, from the lowest: compound 3; then compounds 2, 1 and 4 (each within the scatter of the next).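

In this assay, for the compounds shown here, the change from ethylamino to cyclopropylamino gives a 4.8-fold higher number from compound 3 to compound 4 (0.68 log units; beyond the scatter), the first direct reading of any change at this amine nitrogen. With the rest of the molecule held the same, this position is therefore not indifferent to which small group it carries: here, cyclopropyl in place of ethyl means that more compound is needed for the same effect. Nothing at hand explains why the number rises with this swap.

This single pair cannot tell whether the rise follows the three-membered ring itself or simply the change from ethyl to a larger group, so it gives no general rule for this position. Isopropyl, an open-chain branched group, and cyclobutyl, a larger ring, on the core of compound 3 would help separate those two readings, while it also stays open whether the same swap has a similar effect on the core of compound 2.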